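Chain extension from compound 3 to compound 4

This account rests on a few compounds, and the source may have more. Where it says the series, first, only, none or still open, it means among the compounds named here.

Readings in a functional assay on cells (T-cell line, Homo sapiens) for inhibition (on this read-out lower numbers stand for stronger inhibition and higher numbers for weaker inhibition), are as follows.
- Compound 1 `Clc1ccc(CCCN2CCC(COC(c3ccccc3)c3ccccc3)CC2)cc1` gives (500 nM)
- Compound 2 `COc1cccc(CCCN2CCC(COC(c3ccccc3)c3ccccc3)CC2)c1` gives (1500 nM)
- Compound 3 `CCCCCN1CCC(COC(c2ccccc2)c2ccccc2)CC1` gives (10800 nM)

Compound 3 has the highest number of the three and is the weakest inhibitor, with its steps to both others beyond the scatter. Compound 4 `CCCCCCCN1CCC(COC(c2ccccc2)c2ccccc2)CC1` differs from it by a single change (ethyl in place of hydrogen on a saturated chain carbon, five bonds along the chain from an amine nitrogen in a ring), ethyl in place of hydrogen on a saturated chain carbon, five bonds along the chain from an amine nitrogen in a ring.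

Among the measured compounds shown here, no measured step makes this change. The nearest evidence comes from the same chain, where ethyl replaces an aryl group: a 22-fold higher number from compound 1 to compound 3 (1.33 log units; beyond the scatter) is large and a 7.2-fold higher number from compound 2 to compound 3 (0.86 log units; beyond the scatter) is modest. In both, the ethyl end carries the higher number. The step of a 3.0-fold higher number from compound 1 to compound 2 (0.48 log units; beyond the scatter) shows that the two aryl ends also differ. These steps bear on the chain end only indirectly, and the data hold no plain chain longer than that of compound 3. In this assay a modest step toward a lower number is therefore expected. The estimated step is a 3.1-fold lower number from compound 3 to compound 4 (0.49 log units; beyond the scatter) and it stays uncertain. Compound 4 is estimated at 3500 nM with an expected range of 1200 nM to 10000 nM in this read-out.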

Compound 4, half-maximal inhibitory concentration: 500 nM
Beside the measured number, compound 4's estimate is 7.0-fold (0.85 log units) above it; the whole stated range lies above it.
By their numbers in this assay, from the lowest: compounds 1 and 4 (each within the scatter of the next); then compound 2; then compound 3.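

Lengthening the plain chain at this position is a strong change in this assay (a 22-fold lower number from compound 3 to compound 4 (1.33 log units; beyond the scatter)): ethyl in place of hydrogen, five bonds along the chain from the ring amine nitrogen, carries a large step, whereas the earlier compounds showed only that the plain chain of compound 3 gave a higher number than either aryl-ended chain. An aryl end is therefore not needed to reach the lowest numbers seen in this series, as the plain chain of compound 4 matches the 4-chlorophenyl chain within the scatter (no change at the digits printed from compound 1 to compound 4 (within the scatter)) and lies beyond the scatter from the 3-methoxyphenyl chain (a 3.0-fold lower number from compound 2 to compound 4 (0.48 log units; beyond the scatter)). Nothing in the data accounts for the size of the step.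

Among the compounds shown here, open is whether a longer chain than that of compound 4 would lower the number further or reverse the trend, as only two plain chain lengths are on hand. Also open, as far as these compounds go, is how a chain of this length would respond to an amine or a carboxylic acid at its end.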